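From Furan to Thiophene on the Shared Core

The compounds below may be only part of what the source reports. "The series", "measured", "known", "first", "only" and "open" are said of these compounds alone.

Compound 1 `CCOC(=O)C12C(=O)OCC=C1COC2c1ccccc1F` and compound 2 `CCOC(=O)C12C(=O)OCC=C1COC2c1ccco1` share a core that carries an ethoxycarbonyl group and differ only in the aryl group on a saturated ring carbon. In a functional assay on A549 cells (Homo sapiens) for cytotoxicity, read by MTT assay (a lower number here means a stronger inhibitor, a higher number a weaker inhibitor), compound 1 reaches only the limit of > 1000000 nM. In this assay compound 2 likewise reaches only the limit of > 1000000 nM. The step that the two limits leave unreadable from compound 1 to compound 2 cannot be read because the limit of > 1000000 nM in this assay, at which 2 of the 2 values shown sit, places both values at the ceiling of the assay. Compound 3 `CCOC(=O)C12C(=O)OCC=C1COC2c1cccs1` has not yet been measured; it differs from compound 2 by thiophen-2-yl in place of furan-2-yl on a saturated ring carbon. The only measured step touches the same saturated ring carbon of the core, but its size is unreadable, so nothing shown points to a step in this assay beyond the scatter in either direction, and no pattern can be claimed from two limits. On that basis compound 3 is expected to sit at the limit as well, with an estimated 1000000 nM and a range from 300000 nM to 3000000 nM. The step of a number no higher from compound 2 to compound 3 (the limit leaves the size open) that this estimate implies is expected to be none beyond the scatter.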

Compound 3, half-maximal inhibitory concentration: > 1000000 nM
Compound 3 ended at the assay's limit; the forecaster's own chance of this, stated with the estimate: 85%; the middle value lies on the limit itself.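

In this assay compound 3 gives > 1000000 nM, which is a limit of the assay and not a number. Among these compounds, no step among compound 1, compound 2 and compound 3 can therefore be read: the limit of > 1000000 nM in this assay, at which 3 of the 3 values shown sit. The compounds shown leave open whether any group on this saturated ring carbon of the shared core gives a readable value, and how 2-fluorophenyl, furan-2-yl and thiophen-2-yl truly compare.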